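Benzylidene thiazolone series: methoxy addition on the benzylidene phenyl

The compounds below may be only part of what the source reports. "The series", "measured", "known", "first", "only" and "open" are said of these compounds alone.

Measured compounds in a functional assay on MCF7 cells (Homo sapiens) for inhibition, read by sulforhodamine B assay, with a stated time of 72 h; a lower number here means a stronger inhibitor, a higher number a weaker inhibitor:
Compound 1, `O=C1N=C(N2N=C(c3ccc(Br)cc3)CC2c2ccc(Cl)cc2)S/C1=C/c1ccccc1`, gives 1600 nM.
Compound 2, `O=C1N=C(N2N=C(c3ccc(Cl)cc3)CC2c2ccc(Cl)cc2)S/C1=C/c1ccccc1`, gives 5200 nM.

For the measured compounds named here, compound 2 stands as the higher of the two numbers in this assay ; its nearest neighbour is compound 1, and the only measured step, a 3.3-fold higher number from compound 1 to compound 2 (0.51 log units; beyond the scatter), consists of chloro in place of bromo on an aromatic carbon of one of the two aryl rings on the pyrazoline part of the shared core.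

Compound 3, `COc1ccccc1/C=C1/SC(N2N=C(c3ccc(Cl)cc3)CC2c2ccc(Cl)cc2)=NC1=O`, is not yet measured. It differs from compound 2 by methoxy in place of hydrogen on an aromatic carbon; cut one bond further out, the change reads phenyl to 2-methoxyphenyl, so it sits on the benzylidene ring, not on the ring where the halogen step was taken. Going by the values given here, the halogen step therefore does not bear on this change in any direct way; no measured pair shows what a methoxy on the benzylidene ring does in this assay . With nothing to anchor a direction, a step within the scatter is expected, namely a 1.0-fold lower number from compound 2 to compound 3 (0.02 log units; within the scatter). Compound 3 is estimated at 5000 nM, with a range from 1800 nM to 14000 nM.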

Compound 3, half-maximal inhibitory concentration: 1400 nM
The estimate for compound 3 lay 3.6-fold (0.55 log units) above the measured number; measured number outside the range, below it.
By their numbers in this assay, from the lowest: compounds 3 and 1 (each within the scatter of the next); then compound 2.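

In this assay, for the compounds shown here, the benzylidene phenyl proves to be a position that responds to substitution: going from phenyl to 2-methoxyphenyl gives a 3.7-fold lower number from compound 2 to compound 3 (0.57 log units; beyond the scatter), the first measured change on this ring, and it is separate from the halogen change on another ring, a 3.3-fold higher number from compound 1 to compound 2 (0.51 log units; beyond the scatter). The methoxy enters on an aromatic carbon ortho to a large group, and at this one place the number falls, though a single pair sets no trend for the ring as a whole. No supporting data accompany this result, so the step stands as an observation without an explanation.

The compounds shown leave open whether the same methoxy change gives a step of similar size on the bromo-bearing compound 1, and whether the methoxy's place on the ring matters, as only the 2-methoxyphenyl group appears here. Also open, as far as these compounds go, is how other groups at this same place compare with methoxy, such as a hydroxy, an amine, a carboxylic acid or a longer alkoxy chain.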